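From Thioamide to Carboxamide: What Cytotoxicity to Expect

The source may hold more compounds than are shown below. What is called first, only, known or untested is meant among the compounds shown, and "the series" means these compounds.

Among the measured compounds shown here, compound 2 `NC(=S)c1nn(COCCO)c2ncnc(N)c12` is the only compound here with an actual number: in a functional assay on HFF cells (Homo sapiens) for cytotoxicity (on this read-out higher numbers stand for weaker inhibition and lower numbers for stronger inhibition), compound 2 gives 55000 nM. Compound 1 `COC(=N)c1nn(COCCO)c2ncnc(N)c12` reached only a limit of the assay, and in this assay compound 1 gives > 100000 nM. For the measured compounds named here, the single measured step runs an at least 1.8-fold lower number from compound 1 to compound 2 (0.25 log units; that floor lies within the scatter); its size is known only as a floor because of the limit of > 100000 nM in this assay, at which 1 of the 2 values shown sits. Compound 3 `NC(=O)c1nn(COCCO)c2ncnc(N)c12` differs from compound 2 in one place: a group of 3 heavy atoms (1 carbon, 1 nitrogen, 1 oxygen; no ring) in place of a group of 3 heavy atoms (1 carbon, 1 nitrogen, 1 sulfur; no ring), on an aromatic carbon. This exchange is not the one that was measured, so the step from compound 1 to compound 2 offers only loose guidance, and it gives no sign that swapping the sulfur-bearing group for the carbamoyl group would move the number much. The expected step is therefore a 1.3-fold higher number from compound 2 to compound 3 (0.10 log units; within the scatter), within the usual scatter. Compound 3 is estimated at 70000 nM, with a range from 25000 nM to 200000 nM.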

Compound 3, half-maximal inhibitory concentration: > 100000 nM
Compound 3 ended at the assay's limit; the forecaster's own chance of this, stated with the estimate: 45%; middle value at least 1.4-fold (0.15 log units) from the limit.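

Putting carbamoyl in place of the sulfur-bearing group on this aromatic carbon gives an at least 1.8-fold higher number from compound 2 to compound 3 (0.25 log units; that floor lies within the scatter) in this assay. Among the compounds shown here, this is the first look at an exchange of sulfur for oxygen at this position, and it places a second compound at the limit rather than giving a second true number, so it cannot show that oxygen really weakens the effect. The size of the step is known only as a floor because of where the values sit: the limit of > 100000 nM in this assay, at which 2 of the 3 values shown sit.

The step between compound 1 and compound 3 joins two limits and cannot be read. The compounds shown leave open what a carboxylic acid or a nitrile on this aromatic carbon would give in this assay, and whether a longer chain in place of the (2-hydroxyethoxy)methyl group would change the picture.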